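The source may report more compounds than this note shows. Statements on the series, on what has been measured and on what is new or still open speak of the compounds shown alone.

Of the compounds shown here, three of one shared core have been measured so far. Compound 1, `Cc1ccccc1CCC(=O)N[C@@H](C(=O)N1CCC(c2ccc(Cl)cc2)CC1)C(C)C`, gives 19 nM in an assay on THP-1 cells for displacement of a labelled ligand from C-C chemokine receptor type 1 (Homo sapiens); a lower number here means a stronger inhibitor, a higher number a weaker inhibitor. Compound 3, `Cc1ccccc1C(=O)NC(C(=O)N1CCC(c2ccc(Cl)cc2)CC1)C(C)C`, gives 36 nM in this assay, and compound 2, `CC[C@@H](NC(=O)CC(C)C)C(=O)N1CCC(c2ccc(Cl)cc2)CC1`, gives 152 nM. Compound 1 thus has the lowest number of the three, but its gap to compound 3 lies within the scatter of repeated measurements, so no order between those two can be claimed; only compound 2 stands clearly apart, with a number well beyond the scatter above that of compound 1.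

The step now followed leads from compound 1 to compound 4, `CC(C)[C@@H](NC(=O)Nc1ccccc1)C(=O)N1CCC(c2ccc(Cl)cc2)CC1`, which has not yet been measured. The two structures differ in one place: anilino in place of 2-(2-methylphenyl)ethyl on a carbonyl carbon. The group that leaves carries no hydrogen-bond donor, while the anilino group that enters brings one, and the carbonyl carbon it sits on keeps its amide-type nitrogen neighbour.

For the measured compounds named here, no measured pair shows this exact change, so the expectation rests on the three values alone. Compound 4 is expected to sit somewhat above compound 1, with the step of a 2.6-fold higher number from compound 1 to compound 4 (0.42 log units; beyond the scatter) estimated at roughly the edge of the scatter. For compound 4 the estimate in this assay is 50 nM, with a range from 15 nM to 170 nM.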

Compound 4, half-maximal inhibitory concentration: 616 nM
The estimate for compound 4 lay 12-fold (1.09 log units) below the measured number; measured number above the stated range.
By their numbers in this assay, from the lowest: compounds 1 and 3 (each within the scatter of the next); then compound 2; then compound 4.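

In this assay, anilino in place of 2-(2-methylphenyl)ethyl on this carbonyl carbon gives a 32-fold higher number from compound 1 to compound 4 (1.51 log units; beyond the scatter), a large step showing that the number here depends strongly on which group sits at this position. Both groups carry one six-membered aromatic ring of carbon only, so such a ring alone is not enough to keep the number of compound 1 at 19 nM. The step changes several things at once, since the group that enters is smaller by the heavy-atom count, contains a nitrogen and brings a hydrogen-bond donor, and no data shown here explain the rise or tie it to any one of these differences.

From the compounds shown here alone, it remains open whether the methyl on the ring or the nitrogen on the carbonyl carbon matters more; a 2-methylanilino group and an unsubstituted 2-phenylethyl group at this position would each separate one of these differences from the rest. A benzylamino group, which keeps the nitrogen but adds a carbon to the chain leading to the ring, would test whether the length of that chain also plays a part.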